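A few compounds are considered here, and "the series" means these few. Any claim that something is new, unique, unknown or untested is made for them only; others in the source may bear on it.

Measured so far in a functional assay on HT-29 cells (Homo sapiens) for cytotoxicity, read by MTT assay; on this read-out lower numbers stand for stronger inhibition and higher numbers for weaker inhibition:
Compound 1 `CC(=O)O[C@@H]1OC(=O)[C@@](C(C)=O)(C2SCCCS2)[C@@H]1C` gives > 50000 nM, which is a limit of the assay.
Compound 2 `CC(=O)O[C@@H]1OC(=O)[C@](O)(C(C)=O)[C@@H]1C` gives > 50000 nM, likewise a limit of the assay.
Compound 3 `CC(=O)O[C@@H]1OC(=O)[C@](Br)(C(C)=O)[C@@H]1C` gives 12000 nM.

Among the measured compounds shown here, compound 3 thus holds the only real number; the other two values sit at the limit of > 50000 nM in this assay, at which 2 of the 3 values shown sit. Compound 4 `CC(=O)O[C@@H]1OC(=O)[C@@H](C(C)=O)[C@@H]1C` differs from compound 3 by hydrogen in place of bromo on a saturated ring carbon. For the measured compounds named here, the steps that bear on this position are an at least 4.1-fold lower number from compound 1 to compound 3 (0.61 log units; beyond the scatter) and an at least 4.1-fold lower number from compound 2 to compound 3 (0.61 log units; beyond the scatter), both ending in the lower number of compound 3 once bromo occupies the position. Going by the values given here, no measured step exchanges bromo for hydrogen, so the size is not readable; the expectation is a higher number, a 2.5-fold higher number from compound 3 to compound 4 (0.40 log units; beyond the scatter). Compound 4 is therefore estimated at 30000 nM, with a range from 8000 nM to 60000 nM.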

Compound 4, half-maximal inhibitory concentration: > 50000 nM
Compound 4: only a limit was reported (the forecaster's own chance of this, stated with the estimate: 45%); middle value at least 1.6-fold (0.22 log units) away from the limit.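

Exchanging bromo for hydrogen on this saturated ring carbon gives an at least 4.1-fold higher number from compound 3 to compound 4 (0.61 log units; beyond the scatter), so bare hydrogen at this position does not keep the measurable effect of compound 3. Of the four groups shown here, only bromo gives a real number. The steps from compound 1 and compound 2 to compound 4 cannot be read, and most of the series now rests on one assay limit: the limit of > 50000 nM in this assay, at which 3 of the 4 values shown sit.

From the compounds shown here alone, it remains open whether chloro, iodo or an amine on this carbon would also give a real number. Going by these compounds, how the three compounds at the limit rank against one another also stays unknown.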